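Swapping bromine for fluorine on a second core

A few compounds are considered here, and "the series" means these few. Any claim that something is new, unique, unknown or untested is made for them only; others in the source may bear on it.

Measured compounds:
compound 1, `CS(=O)(=O)c1ccc(-c2nc(SCCCOC(=O)/C=C/c3ccc(O)c(O)c3)nn2-c2ccc(Br)cc2)cc1`, 790 nM
compound 2, `CS(=O)(=O)c1ccc(-c2nc(SCCCOC(=O)/C=C/c3ccc(O)c(O)c3)nn2-c2ccc(F)cc2)cc1`, 710 nM
compound 3, `COc1cc(/C=C/C(=O)OCCSc2nc(-c3ccc(S(C)(=O)=O)cc3)n(-c3ccc(Br)cc3)n2)ccc1OC(C)=O`, 940 nM

In an assay on cells (strain Sprague-Dawley) for inhibition of Polyunsaturated fatty acid 5-lipoxygenase (Rattus norvegicus), with a stated time of 30 min (on this read-out higher numbers stand for weaker inhibition and lower numbers for stronger inhibition), compound 1 and compound 2 differ by one change, (fluoro in place of bromo on an aromatic carbon). That change gave a 1.1-fold lower number from compound 1 to compound 2 (0.05 log units; within the scatter), a step too small to tell apart from repeat measurements. Compound 3 belongs to a different core; how its core differs from that of compound 1 is not broken down here. Compound 4, `COc1cc(/C=C/C(=O)OCCSc2nc(-c3ccc(S(C)(=O)=O)cc3)n(-c3ccc(F)cc3)n2)ccc1OC(C)=O`, has not yet been measured. It is made from compound 3 by fluoro in place of bromo on an aromatic carbon, the same change as from compound 1 to compound 2, at the same kind of place. Because a 1.1-fold lower number from compound 1 to compound 2 (0.05 log units; within the scatter) was within the scatter, the step from compound 3 to compound 4 is expected to be small too, a 1.1-fold lower number from compound 3 to compound 4 (0.04 log units; within the scatter). Compound 4 is estimated at 850 nM, between 450 nM and 1600 nM.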

Compound 4, half-maximal inhibitory concentration: 920 nM
The estimate for compound 4 lay 1.1-fold (0.03 log units) below the measured number; the measured number falls inside the stated range.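

In this assay, going by these compounds alone, replacing 4-bromophenyl with 4-fluorophenyl on the second core gave a 1.0-fold lower number from compound 3 to compound 4 (0.01 log units; within the scatter), so here too the swap produced no step that can be told apart from repeat measurements. Set side by side, the steps on the two cores agree: the same change on two cores in this assay, a 1.1-fold lower number (0.05 log units; within the scatter) from compound 1 to compound 2 and a 1.0-fold lower number (0.01 log units; within the scatter) from compound 3 to compound 4, 1.1-fold (0.04 log units) apart, within the scatter of two such steps. Within the data shown here, this shows that the swap left the number within the scatter on both cores, but it rests on only two pairs, so it does not show that the same would hold on other cores, or that a change with a larger step would carry over as well.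

The compounds shown leave open what a group of a different kind, such as an amine or a nitrile, would do on that same aromatic carbon. They also leave open whether a longer chain carrying the ester would alter the number.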